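This account rests on a few compounds, and the source may have more. Where it says the series, first, only, none or still open, it means among the compounds named here.

Measured compounds:
- compound 1 `O=C(N/N=C/c1ccc(Br)cc1)Nc1cccc2ccccc12`: 300 mg/kg
- compound 2 `C/C(=N\NC(=O)Nc1cccc2ccccc12)c1ccc(Cl)cc1Cl`: 300 mg/kg
- compound 3 `O=C(N/N=C/c1ccccc1[N+](=O)[O-])Nc1cccc2ccccc12`: 300 mg/kg

In a functional assay on the whole organism (strain Swiss albino) with Mus musculus as the target, in the maximal electroshock model, with a stated time of 4 h (a lower number here means that less compound is needed, a higher number that more compound is needed for the effect), compound 1 gives 300 mg/kg. Compound 2 gives 300 mg/kg, and compound 3 gives 300 mg/kg. At the digits shown the three stand level, so nothing separates compound 1 from either of the others beyond the usual scatter of this kind of measurement. Among the measured compounds shown here, no pair of measured compounds differs in only one place, so no single step can be read from the measured set.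

Compound 4 `O=C(N/N=C/c1ccc(F)cc1)Nc1cccc2ccccc12` has not yet been measured. It differs from compound 1 in one place: fluoro in place of bromo on an aromatic carbon. The bromo leaves and a fluoro enters on the same aromatic carbon; what is counted stays the same, and the shared core is untouched.

For the measured compounds named here, with no measured step to lean on, the expectation for no change at the digits printed from compound 1 to compound 4 (within the scatter) is a change that stays within the scatter, in no particular direction, because compound 1 gives 300 mg/kg and the other two measured compounds sit at the same value. Compound 4 is accordingly expected at 300 mg/kg, with a likely range from 100 mg/kg to 600 mg/kg.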

Compound 4, minimum effective dose: 300 mg/kg
For compound 4 middle estimate and measured number coincide at the digits printed, within the range that was stated.
By their numbers in this assay, from the lowest: compounds 1, 2, 3 and 4 (each within the scatter of the next).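

Among the compounds shown here, the first comparison of compounds that differ in only one place comes from the change from 4-bromophenyl to 4-fluorophenyl, which gives no change at the digits printed from compound 1 to compound 4 (within the scatter) in this assay. For the compounds shown here, at this aromatic carbon, para to a large group, bromo and fluoro therefore cannot be told apart by this read-out, a point the earlier compounds could not show because none of them formed such a pair. Nothing available explains why the two compounds match.

On these data alone, only these two halogens are compared at this position, so it remains open whether an amine, a carboxylic acid or a longer chain on the same carbon would change the dose needed. Compounds 2 and 3 differ from the others in more than one place, so no steps can be read for them.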